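The source may report more compounds than this note shows. Statements on the series, on what has been measured and on what is new or still open speak of the compounds shown alone.

Working notes on the series. Compound 1 `O=C(NCc1cn(Cc2ccc(C(F)(F)F)cc2)nn1)c1cn(-c2ccccc2)nc1-c1ccccc1` gives 1600 nM in a functional assay on HeLa cells (Homo sapiens) for antiproliferative activity, read by sulforhodamine B assay, with a stated time of 48 h; on this read-out lower numbers stand for stronger inhibition of growth and higher numbers for weaker inhibition of growth. Compound 2 `O=C(NCc1cn(Cc2ccc(C(F)(F)F)cc2)nn1)c1cn(-c2ccccc2)nc1-c1ccc(F)cc1` gives 250 nM in this assay, and compound 3 `O=C(NCc1cn(Cc2ccc(C(F)(F)F)cc2)nn1)c1cn(-c2ccccc2)nc1-c1ccc(Cl)cc1` gives 1900 nM. Compound 3 stands highest of the three numbers: the step of a 1.2-fold higher number from compound 1 to compound 3 (0.07 log units; within the scatter) is within the scatter, while a 7.6-fold higher number from compound 2 to compound 3 (0.88 log units; beyond the scatter) and a 6.4-fold lower number from compound 1 to compound 2 (0.81 log units; beyond the scatter) lie beyond it. Compound 4 `COc1cc(Cn2cc(CNC(=O)c3cn(-c4ccccc4)nc3-c3ccc(Cl)cc3)nn2)cc(OC)c1OC` differs from compound 3 by 3,4,5-trimethoxyphenyl in place of 4-(trifluoromethyl)phenyl on a saturated chain carbon bound to an aromatic nitrogen. For the measured compounds named here, all three measured steps concern substitution on the aryl ring attached to the core, and none touches the group on the saturated chain carbon bound to an aromatic nitrogen; no measured step therefore bears on this change, and the direction of any effect is unknown from these data. In this assay the expected step is accordingly none beyond the scatter, given only as no change at the digits printed from compound 3 to compound 4 (within the scatter), with a wide range to reflect the absence of a comparable measured step. Compound 4 is estimated at 1900 nM, between 400 nM and 9000 nM.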

Compound 4, concentration for 50% growth inhibition: 100 nM
Compound 4: the middle estimate sits 19-fold (1.28 log units) above what was measured, outside the stated range (below it).
By their numbers in this assay, from the lowest: compound 4; then compound 2; then compounds 1 and 3 (each within the scatter of the next).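

In this assay, for the compounds shown here, the group on the saturated chain carbon bound to an aromatic nitrogen proves to matter: 3,4,5-trimethoxyphenyl in place of 4-(trifluoromethyl)phenyl gives a 19-fold lower number from compound 3 to compound 4 (1.28 log units; beyond the scatter), the first measured step at this position. The change replaces three fluorine atoms with three methoxy groups and brings the hydrogen-bond acceptor count of the group from 0 to 3, but this single step cannot show which difference carries the effect. No supporting measurement is available to explain the step.

On these data alone, it remains open whether the same change would give a similar step with the fluoro or unsubstituted aryl ring of compound 2 or compound 1. As far as these compounds go, it is also open whether a phenyl carrying one methoxy group, or a dimethylamino group, would hold the step seen with compound 4.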